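This account rests on a few compounds, and the source may have more. Where it says the series, first, only, none or still open, it means among the compounds named here.

In a functional assay on NCI-H23 cells (Homo sapiens) for antiproliferative activity, read by XTT assay (a higher number here means a weaker inhibitor, a lower number a stronger inhibitor), compound 1 `O=c1c(Cc2coc3cccc(OCC4CCCCC4)c3c2=O)coc2ccccc12` gives 4130 nM, compound 2 `O=c1c(Cc2coc3ccccc3c2=O)coc2ccccc12` gives 1400 nM and compound 3 `O=c1c(Cc2coc3cccc(O)c3c2=O)coc2ccccc12` gives 7550 nM. Compound 3 sits at the high end of this small set alongside compound 1, with a 1.8-fold higher number from compound 1 to compound 3 (0.26 log units; within the scatter), whereas the comparison with compound 2 shows a 5.4-fold higher number from compound 2 to compound 3 (0.73 log units; beyond the scatter). Compound 4 `COc1cccc2occ(Cc3coc4ccccc4c3=O)c(=O)c12` turns the hydroxy of compound 3 into methoxy: methyl in place of hydrogen on an oxygen on an aromatic ring. Compound 1 also has a group in place of that hydrogen, cyclohexylmethyl, so its step to compound 3 is the closest guide, and it stayed within the scatter. The other relevant comparison, a 3.0-fold lower number from compound 1 to compound 2 (0.47 log units; beyond the scatter), shows that removing the whole oxygen substituent matters more. A small shift towards a lower number is therefore expected, but none beyond the scatter, and the estimated step is a 1.9-fold lower number from compound 3 to compound 4 (0.28 log units; within the scatter). For compound 4 the estimate is 4000 nM, with an expected range of 1500 nM to 10000 nM.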

Compound 4, half-maximal inhibitory concentration: 1930 nM
Beside the measured number, compound 4's estimate is 2.1-fold (0.32 log units) above it; low and high end bracket the measured number.
By their numbers in this assay, from the lowest: compounds 2 and 4 (each within the scatter of the next); then compounds 1 and 3 (each within the scatter of the next).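

A single methyl on this oxygen is enough to move the number in this assay: a 3.9-fold lower number from compound 3 to compound 4 (0.59 log units; beyond the scatter). With methoxy in place of hydrogen the picture barely moves, a 1.4-fold higher number from compound 2 to compound 4 (0.14 log units; within the scatter), so an oxygen substituent at this position does not by itself go with the higher numbers. What sits on that oxygen counts, as the swap from cyclohexylmethoxy to methoxy shows: a 2.1-fold lower number from compound 1 to compound 4 (0.33 log units; beyond the scatter). As far as these compounds go, how an ethoxy group, a longer chain or an amine on this position would read stays open. No measurement shown here explains these steps.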